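The source may hold more compounds than are shown below. What is called first, only, known or untested is meant among the compounds shown, and "the series" means these compounds.

Measured compounds:
compound 1 `Cc1ccc(S(=O)(=O)c2cnc3c(F)cccc3c2-c2ccc(F)cc2)cc1F`, 2.75 mL/min
compound 2 `O=S(=O)(c1cc(F)cc(F)c1)c1cnc2c(F)cccc2c1-c1cccc(F)c1`, 1.18 mL/min

In an ADME assay on microsomes from liver (Homo sapiens) for metabolic stability, tested at 2.5 uM (on this read-out lower numbers stand for slow clearance and higher numbers for fast clearance), compound 1 gives 2.75 mL/min. In this assay compound 2 gives 1.18 mL/min, which is the lowest of the two numbers; compound 1 stands higher by a gap that lies beyond the usual scatter, so compound 2 is the more slowly cleared of the pair.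

Compound 3 `Cc1ccc(S(=O)(=O)c2cnc3c(F)cccc3c2-c2cccc(F)c2)cc1F` has not yet been measured. It differs from compound 2 in one place: 3-fluoro-4-methylphenyl in place of 3,5-difluorophenyl on a sulfonyl sulfur. The group that enters is the same 3-fluoro-4-methylphenyl that compound 1 carries on its sulfonyl sulfur, while the remainder of compound 3 stays as in compound 2. Among the compounds with values here, no direct step between two measured compounds covers this exact change, so only the two values above can guide an expectation. Since compound 1 gives 2.75 mL/min and compound 2 gives 1.18 mL/min, compound 3 is expected to land between them, with its clearance rising from compound 2 by a step of roughly a 1.7-fold higher number from compound 2 to compound 3 (0.23 log units; within the scatter). The estimate for compound 3 is therefore 2 mL/min, in a range from 1 mL/min to 4 mL/min.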

Compound 3, intrinsic clearance in a liver preparation (reported as CLH), per the amount of preparation that the assay uses: 3.92 mL/min
Estimate against measurement, compound 3: 2.0-fold (0.29 log units) below; the range from low to high includes it.
By their numbers in this assay, from the lowest: compound 2; then compounds 1 and 3 (each within the scatter of the next).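

Within the data shown here, on the sulfonyl sulfur, 3-fluoro-4-methylphenyl in place of 3,5-difluorophenyl gives a 3.3-fold higher number from compound 2 to compound 3 (0.52 log units; beyond the scatter) in this assay, which is the first reading of this exchange with the rest of the molecule held the same. With 3-fluoro-4-methylphenyl on the sulfonyl sulfur, 3-fluorophenyl in place of 4-fluorophenyl on an aromatic carbon gives a 1.4-fold higher number from compound 1 to compound 3 (0.15 log units; within the scatter) and so separates neither compound, which means that among these three compounds only the exchange on the sulfonyl sulfur moves the number beyond the scatter. Nothing available explains why this exchange raises the number.

Among these compounds, whether the step on the sulfonyl sulfur would be of similar size with 4-fluorophenyl in place of 3-fluorophenyl on the aromatic carbon remains open, since it has been read with only one such group. The compounds shown also leave open how a group of a different kind on the sulfonyl sulfur, such as an unsubstituted phenyl, a pyridine or a simple amine, would stand in this read-out.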